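Thiophene-bearing sulfonamides on guinea-pig ileum: the unassigned stereocentre

The source may report more compounds than this note shows. Statements on the series, on what has been measured and on what is new or still open speak of the compounds shown alone.

Measured so far in a functional assay on ileum (Cavia porcellus) for inhibition; a lower number here means a stronger inhibitor, a higher number a weaker inhibitor:
Compound 1, `C=CCN(c1ccccc1)S(=O)(=O)c1ccc(Cl)cc1`, gives 4320 nM.
Compound 2, `O=S(=O)(c1ccc(Cl)cc1)N1CCC[C@@H]1c1cccs1`, gives 1070 nM.
Compound 3, `O=S(=O)(c1ccc(Cl)cc1)N1CCC[C@H]1c1cccs1`, gives 2060 nM.

Compound 2 has the lowest of the three numbers; its nearest neighbour is compound 3, and compound 1 lies furthest from it. Compound 4, `O=S(=O)(c1ccc(Cl)cc1)N1CCCC1c1cccs1`, differs from compound 2 as follows: the two compounds have the same atoms and bonds; at least one stereo element is drawn with a configuration in one of them and without one in the other: 1 of 1 stereo elements differ; a stereocentre at a saturated ring carbon is drawn R in compound 2 and without a configuration in compound 4. For the measured compounds named here, the only measured step that bears on this change is a 1.9-fold higher number from compound 2 to compound 3 (0.28 log units; within the scatter), notable because of the fact that compounds 2 and 3 differ only in the configuration as drawn: the two drawn configurations give numbers within the scatter of each other. Compound 4, drawn without a configuration, is therefore expected to fall near both, with a step of a 1.4-fold higher number from compound 2 to compound 4 (0.13 log units; within the scatter) and no change beyond the scatter. Compound 4 is estimated at 1450 nM, with a range from 800 nM to 2700 nM.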

Compound 4, half-maximal inhibitory concentration: 1180 nM
The estimate for compound 4 lay 1.2-fold (0.09 log units) above the measured number; measured number inside the range.
By their numbers in this assay, from the lowest: compounds 2, 4 and 3 (each within the scatter of the next); then compound 1.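

Drawn without a configuration, compound 4 stays within the scatter of both drawn forms in this assay, with a 1.1-fold higher number from compound 2 to compound 4 (0.04 log units; within the scatter) and a 1.7-fold lower number from compound 3 to compound 4 (0.24 log units; within the scatter). The earlier pair had set only the two drawn forms side by side, and leaving the stereocentre undefined opens no separation either. Each new step rests on a single difference at that stereocentre: the fact that one of compounds 2 and 4 is drawn with a defined configuration and the other without, at the place where they differ

The compounds shown do not tell whether compound 4 is a mixture of both forms. As far as these compounds go, whether this stereocentre would count for more on a core carrying an amine or a carboxylic acid also stays open.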